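Tetrazolylacetamides at Kir3.1/Kir3.2: from compound 3 to compound 4

The compounds below may be only part of what the source reports. "The series", "measured", "known", "first", "only" and "open" are said of these compounds alone.

Three tetrazolylacetamides have been run in an assay on HEK293 cells for activation of Kir3.1/Kir3.2 (Homo sapiens), read by thallium flux; a lower number here means a smaller maximal response, a higher number a larger maximal response. Compound 1 `Cc1nc(NC(=O)Cn2nnc(-c3ccccc3)n2)n(-c2ccccc2)n1` and compound 2 `O=C(Cn1nnc(-c2ccccc2)n1)Nc1ccccn1` both come back without a number: in this assay compound 1 is reported as "not active" (no number reported) and compound 2 as "not active" (no number reported). Compound 3 `Cc1cc(NC(=O)Cn2nnc(-c3ccc(Cl)c(Cl)c3)n2)n(C2CCCCC2)n1` is the only member with a measured response; in this assay compound 3 reaches 84%, so among the entries shown it stands alone at the top, with nothing to compare it to by number.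

Compound 4 `Cc1cc(NC(=O)Cn2nnc(-c3cccc(F)n3)n2)n(C2CCCCC2)n1` differs from compound 3 in one place: 6-fluoropyridin-2-yl in place of 3,4-dichlorophenyl on an aromatic carbon. For the measured compounds named here, no measured pair with this change exists, so the size of the step is open. Given that compound 3 delivers 84% while two further members of the series give no response at all, a drop beyond the scatter is expected rather than a gain, with a real chance that compound 4 also returns no number.

The estimate for compound 4 in this assay is 55%, within 20% to 90%, which as a step means a number 29 percentage points lower from compound 3 to compound 4 (beyond the scatter).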

Compound 4, largest response reached (Emax), in percent of the reference or control that the assay uses: > 83%
Compound 4 ended at the assay's limit; the forecaster's own chance of this, stated with the estimate: 30%; at least 28 percentage points between middle value and limit.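

In this assay, for the compounds shown here, compound 4 gives > 83%, which is a limit of the assay and not a number, so no step from compound 3 to compound 4 can be read. The compounds shown leave open whether 6-fluoropyridin-2-yl in place of 3,4-dichlorophenyl changes the maximal response at all.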